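The compounds below may be only part of what the source reports. "The series", "measured", "known", "first", "only" and "open" are said of these compounds alone.

Two compounds of this series have been run in an assay on CHO cells for displacement of a labelled ligand from adenosine receptor A3 (Homo sapiens), read by scintillation counting, tested at 10 uM (a higher number here means more inhibition at the concentration tested (going by the name of the read-out), a lower number less inhibition), so far. Compound 1 `Cc1c(Br)sc(N)c1C(=O)c1ccc(Cl)cc1` gives 1% there, and compound 2 `CC(C)(C)Cc1c(-c2ccc(F)cc2)sc(N)c1C(=O)c1ccc(Cl)cc1` gives 9%; the two numbers sit within the usual scatter of each other, and neither shows much displacement at the tested concentration. Compound 3 `COc1cccc(-c2sc(N)c(C(=O)c3ccc(Cl)cc3)c2CC(C)(C)C)c1` is the next one to be measured. It differs from compound 2 in one place: 3-methoxyphenyl in place of 4-fluorophenyl on an aromatic carbon. Going by the values given here, no step between measured compounds is available to guide this change, so compound 3 is expected to stay close to compound 2, with a step of a number 1 percentage points higher from compound 2 to compound 3 (within the scatter) that does not go beyond the scatter. For compound 3 the estimated inhibition is 10%, in the range 0% to 25%.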

Compound 3, a percentage reported as inhibition, at one concentration (the size of the read-out at that concentration, not a potency): 1%
Beside the measured number, compound 3's estimate is 9 percentage points above it, and the stated range covers the measured number.
By their numbers in this assay, from the lowest: compounds 1, 3 and 2 (each within the scatter of the next).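

Swapping 4-fluorophenyl for 3-methoxyphenyl on the aromatic carbon next to the ring sulfur gives a number 8 percentage points lower from compound 2 to compound 3 (within the scatter) in this assay. This first step at this position therefore does not separate the two aryl groups, and the added hydrogen-bond acceptor of 3-methoxyphenyl brings no reading beyond the scatter. Nothing available bears on why this is so.

Still open, on these data alone, is whether a carboxylic acid or an aminomethyl group on this phenyl ring, or a morpholine in its place, would move the number beyond the scatter in this assay.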